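Chalcones on a furan-fused core: methoxy step

A few compounds are considered here, and "the series" means these few. Any claim that something is new, unique, unknown or untested is made for them only; others in the source may bear on it.

Measured so far:
compound 1, `O=C(/C=C/c1ccccc1)c1ccc2occc2c1O`, 20.8%
compound 2, `O=C(/C=C/c1ccc(O)c(O)c1)c1ccc2occc2c1O`, 61.5%
compound 3, `O=C(/C=C/c1ccccc1)c1cc2ccoc2cc1O`, 67.6%

The three compounds were tested in an assay on isolated protein for inhibition of lysosomal alpha-glucosidase (Rattus norvegicus), read by spectrophotometry, with a stated time of 5 min, tested at 25 ug/mL; a lower number here means less inhibition, a higher number more inhibition at the concentration tested (going by the name of the read-out). Compound 1 gives 20.8%, compound 2 gives 61.5% and compound 3 gives 67.6%. Compound 3 holds the highest of the three numbers. Within the data shown here, its nearest neighbour is compound 2, whose number is within the usual scatter of the one for compound 3, so the two cannot be ranked against each other. Compound 1 stands furthest away, its number being lower than that of compound 3 by more than the scatter.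

Compound 4 is `COc1ccc(/C=C/C(=O)c2cc3ccoc3cc2O)cc1`, not yet measured in this assay. Relative to compound 3 the change is methoxy in place of hydrogen on an aromatic carbon.

Among the measured compounds shown here, nothing measured here shows what a methoxy group does on this core, and no measured pair differs in just one place. Compound 2 against compound 1 shows a higher number with two hydroxy groups on that ring, but on a different core, so it gives only a loose hint. For compound 4 the expected step of a number 2.6 percentage points lower from compound 3 to compound 4 (within the scatter) is small, in no clear direction, and likely within the scatter. Compound 4 is therefore estimated at 65%, within 45% to 85%.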

Compound 4, a percentage reported as inhibition, at one concentration (the size of the read-out at that concentration, not a potency): 48.9%
Beside the measured number, compound 4's estimate is 16.1 percentage points above it, within the range that was stated.
By their numbers in this assay, from the lowest: compound 1; then compound 4; then compounds 2 and 3 (each within the scatter of the next).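

Methoxy in place of hydrogen, on an aromatic carbon para to a large group, provides the first comparison in the series that differs in one place only: in this assay the change gives a number 18.7 percentage points lower from compound 3 to compound 4 (beyond the scatter). The earlier compounds shown here offered no such pair, so the effect of this position could not be read from them; this step shows that the position is not indifferent to substitution on the core of compound 3, and that a methoxy group there costs inhibition at the concentration tested. Why the number falls cannot be stated, as no supporting data bear on this result.

One step at one position leaves open whether the loss belongs to methoxy itself or would follow from any group placed there, such as a hydroxy group, a fluorine atom, an amine or a carboxylic acid. Also open, as far as these compounds go, is whether methoxy would give a step of similar size and the same direction on the core of compound 1, or at another carbon of the same ring.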